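The compounds below may be only part of what the source reports. "The series", "measured", "known", "first", "only" and "open" are said of these compounds alone.

In an ADME assay on HepG2 2.2.15 cells (Homo sapiens) for cytotoxicity, read by luminescence, with a stated time of 3 days (a lower number here means that less compound is tolerated, a higher number that more compound is tolerated), three compounds that share one core and differ only in the ring on the sulfonyl sulfur have been measured. Compound 1 `O=C(Nc1ccc(F)c(Cl)c1)c1ccc(F)c(S(=O)(=O)N2CCSCC(O)C2)c1` gives 19000 nM as its reading, compound 2 `O=C(Nc1ccc(F)c(Cl)c1)c1ccc(F)c(S(=O)(=O)N2CCOC[C@H](O)C2)c1` gives 19000 nM as its reading, and compound 3 `CN1CCN(S(=O)(=O)c2cc(C(=O)Nc3ccc(F)c(Cl)c3)ccc2F)CC(O)C1` gives 31000 nM as its reading. Compound 3 thus sits level with the other two: the measured steps are a 1.6-fold higher number from compound 1 to compound 3 (0.21 log units; within the scatter) and a 1.6-fold higher number from compound 2 to compound 3 (0.21 log units; within the scatter) and neither leaves the scatter, while no change at the digits printed from compound 1 to compound 2 (within the scatter) completes the picture.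

Compound 4 `CC1(O)CCCN(S(=O)(=O)c2cc(C(=O)Nc3ccc(F)c(Cl)c3)ccc2F)CC1` differs from compound 3 in that ring: 4-hydroxy-4-methylazepan-1-yl in place of 6-hydroxy-4-methyl-1,4-diazepan-1-yl on a sulfonyl sulfur on the same sulfonyl sulfur. All three measured steps swap one ring hetero atom for another, among sulfur, oxygen and methyl-bearing nitrogen, and none of them moved the reading in this assay beyond the scatter. None of them makes the exchange found in compound 4, so the precedent is only indirect. Going by compound 3 and the small size of a 1.6-fold higher number from compound 2 to compound 3 (0.21 log units; within the scatter) in particular, no step beyond the scatter is expected, in either direction. The expected change is a 1.4-fold lower number from compound 3 to compound 4 (0.15 log units; within the scatter) and it is estimated to stay within the scatter. For compound 4 the estimated value is 22000 nM with an expected range from 10000 nM to 45000 nM for this read-out.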

Compound 4, half-maximal cytotoxic concentration: 11000 nM
Beside the measured number, compound 4's estimate is 2.0-fold (0.30 log units) above it; the range from low to high includes it.
By their numbers in this assay, from the lowest: compounds 4, 1, 2 and 3 (each within the scatter of the next, the first and the last beyond it).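

In this assay, among these compounds, going from a ring with a methyl-bearing nitrogen to 4-hydroxy-4-methylazepan-1-yl on the sulfonyl sulfur gives the only step in this set that leaves the scatter (a 2.8-fold lower number from compound 3 to compound 4 (0.45 log units; beyond the scatter)), so this position is not wholly indifferent to the ring placed there. The effect is modest and depends on the comparison, as compound 4 stays within the scatter of the sulfur and oxygen rings (a 1.7-fold lower number from compound 2 to compound 4 (0.24 log units; within the scatter); a 1.7-fold lower number from compound 1 to compound 4 (0.24 log units; within the scatter)), and only compound 3 is separated from it. No measurement shown here accounts for this step.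

The change also alters more than one feature at once, since the ring loses a hetero atom while the names show the hydroxy and methyl groups in different places, so a ring such as 6-hydroxyazepan-1-yl would be needed to tell these apart. Every ring shown carries a hydroxy group, which leaves open how this read-out would respond to an amine such as dimethylamino, or a carboxylic acid, in its place.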